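Trifluoromethoxy in place of methyl, with only limits so far

The source may report more compounds than this note shows. Statements on the series, on what has been measured and on what is new or still open speak of the compounds shown alone.

In an ADME assay on HepG2 cells (Homo sapiens) for cytotoxicity, with a stated time of 72 h (a higher number here means that more compound is needed for the effect, a lower number that less compound is needed), compound 2 `Cc1ccc(NC(=O)Nc2cc(C)nc3ccccc23)cc1` gives > 25000 nM as a limit of the assay, not a number. Compound 1 `Cc1cc(NC(=O)Nc2ccc(C)c(Cl)c2)c2ccccc2n1` gives > 25000 nM as a limit too. Compound 3 `Cc1cc(NC(=O)Nc2cccc(F)c2)c2ccccc2n1` gives > 25000 nM as a limit too. The series therefore shows the limit of > 25000 nM in this assay, at which 3 of the 3 values shown sit, and offers no number against which compound 2 can be placed.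

Compound 4 `Cc1cc(NC(=O)Nc2ccc(OC(F)(F)F)cc2)c2ccccc2n1` is still unmeasured. It carries trifluoromethoxy in place of methyl on an aromatic carbon, para to a large group, and the count of that change is trifluoromethoxy in place of methyl on an aromatic carbon in full.

For the measured compounds named here, two measured steps bear on this change. Hydrogen in place of chloro on an aromatic carbon is a step that the two limits leave unreadable from compound 1 to compound 2 and 3-fluorophenyl in place of 4-methylphenyl on an amide-type nitrogen is a step that the two limits leave unreadable from compound 2 to compound 3 so neither gives a size to carry over. Compound 2 remains the only reference, at > 25000 nM as a limit, and the other two compounds sit at the same limit.

No step beyond the scatter is therefore expected, and the estimated change is a number no higher from compound 2 to compound 4 (the limit leaves the size open) with a report as a limit again likely. For compound 4 the estimated value of 25000 nM comes with an expected range from 10000 nM to 50000 nM if a number is reported at all.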

Compound 4, half-maximal effective concentration: 15000 nM
Beside the measured number, compound 4's estimate is 1.7-fold (0.22 log units) above it; the measured number falls inside the stated range.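

In this assay, trifluoromethoxy in place of methyl on an aromatic carbon, para to a large group, is the only change shown that brings a reading inside the measurable range: the limit of > 25000 nM in this assay, at which 3 of the 4 values shown sit.

Going by these compounds, the change gives an at least 1.6-fold lower number from compound 2 to compound 4 (0.22 log units; that floor lies within the scatter), and since compound 2 is held at a limit, only this floor can be read while the full size of the step stays open. For the compounds shown here, compound 4 thus gives the series its single number in this assay, a reference that the earlier compounds, all at the limit, could not offer for this position.

One pair cannot tell whether the number belongs to trifluoromethoxy as such or to what is counted with it, the added heavy atoms and the hydrogen-bond acceptor that enters at this carbon. Also open, on these data alone, is how methoxy, trifluoromethyl, an amine or a carboxylic acid at the same position would read, and whether the same change would give a number on a ring carrying the chloro of compound 1.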